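Three Alkynyl Amines and a Dimethylamino Prediction

A few compounds are considered here, and "the series" means these few. Any claim that something is new, unique, unknown or untested is made for them only; others in the source may bear on it.

Values in an ADME assay on HepG2 cells (Homo sapiens) for cytotoxicity (on this read-out lower numbers stand for higher toxicity in this test and higher numbers for lower toxicity in this test), for the measured compounds
Compound 1 `CCOC(=O)CN(C)CC#Cc1cc2ncnc(Nc3ccc(OCc4cccc(F)c4)c(Cl)c3)c2s1` gives 26 uM
Compound 2 `CC(C)(C)CC#Cc1cc2ncnc(Nc3ccc(OCc4cccc(F)c4)c(Cl)c3)c2s1` gives 29.3 uM
Compound 3 `CCCN(CC#Cc1cc2ncnc(Nc3ccc(OCc4cccc(F)c4)c(Cl)c3)c2s1)CCC` gives 26.5 uM

Compound 3 (26.5 uM) sits within the scatter of both compound 1 and compound 2. The step to compound 4 (`CN(C)CC#Cc1cc2ncnc(Nc3ccc(OCc4cccc(F)c4)c(Cl)c3)c2s1`) is a single change (dimethylamino in place of dipropylamino on a saturated chain carbon bound to a triple-bonded carbon), dimethylamino in place of dipropylamino on a saturated chain carbon bound to a triple-bonded carbon. Three measured steps at this same place bear on it (a 1.1-fold higher number from compound 1 to compound 2 (0.05 log units; within the scatter)), (a 1.0-fold higher number from compound 1 to compound 3 (0.01 log units; within the scatter)) and (a 1.1-fold lower number from compound 2 to compound 3 (0.04 log units; within the scatter)), and each lies within the scatter. Within the data shown here, no measured compound carries dimethylamino, so the expectation rests on other groups alone. No change beyond the scatter is therefore expected in this assay here. The expected step is small (a 1.0-fold lower number from compound 3 to compound 4 (0.01 log units; within the scatter)). Compound 4 is estimated at 26 uM (expected range 14 uM to 45 uM).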

Compound 4, half-maximal toxic concentration: > 32 uM
Compound 4: only a limit was reported; the forecaster's own chance of this, stated with the estimate: 5%; middle value at least 1.2-fold (0.09 log units) away from the limit.
By their numbers in this assay, from the lowest: compounds 1, 3 and 2 (each within the scatter of the next). At a limit, above all of these: compound 4.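

In this assay compound 4 gives > 32 uM, which is a limit and not a number. Against the other compounds, the data give an at least 1.2-fold higher number from compound 3 to compound 4 (0.08 log units; that floor lies within the scatter), an at least 1.0-fold higher number from compound 2 to compound 4 (0.03 log units; that floor lies within the scatter) and an at least 1.2-fold higher number from compound 1 to compound 4 (0.09 log units; that floor lies within the scatter). This position on the saturated chain carbon therefore carries dimethylamino as well as dipropylamino with no sign of higher toxicity in this test, though each floor remains within the scatter.

On these data alone, how far the value of compound 4 lies past the limit stays open. So does whether a morpholine or a carboxylic acid at this place would keep the number in this range.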